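The source may report more compounds than this note shows. Statements on the series, on what has been measured and on what is new or still open speak of the compounds shown alone.

Compound 1, `O=C(/C=C/c1ccc(F)cc1)NS(=O)(=O)c1ccccc1`: 2.1 ug/mL
Compound 2, `O=C(/C=C/c1ccc(F)cc1)NS(=O)(=O)c1ccc(F)cc1`: 0.8 ug/mL
Compound 3, `O=C(/C=C/c1ccc(F)cc1)NS(=O)(=O)c1ccc(Br)cc1`: 2.8 ug/mL

In a functional assay on B16-F10 cells (Mus musculus) for antiproliferative activity, read by ELISA and MTT assay, with a stated time of 48 h (on this read-out higher numbers stand for weaker inhibition and lower numbers for stronger inhibition), compound 1 gives the second highest of the three numbers. Its nearest neighbour is compound 3, reached by a 1.3-fold higher number from compound 1 to compound 3 (0.12 log units; within the scatter); its furthest is compound 2, reached by a 2.6-fold lower number from compound 1 to compound 2 (0.42 log units; beyond the scatter). Between those two, a 3.5-fold higher number from compound 2 to compound 3 (0.54 log units; beyond the scatter) is the largest step on record, and even that is modest.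

Compound 4, `CN(C)c1ccc(/C=C/C(=O)NS(=O)(=O)c2ccccc2)cc1`, has not been measured. It differs from compound 1 by dimethylamino in place of fluoro on an aromatic carbon. None of the three measured steps touches this fluoro: all of them concern a hydrogen, fluoro or bromo on another aromatic carbon of the shared core. They show only that swapping small substituents on that other carbon moves this assay by a modest amount at most, with one step within the scatter. Dimethylamino in place of fluoro is a larger change, and no measured pair speaks to it directly, so the direction is open. Compound 4 is therefore expected to land near compound 1, with a wide margin on either side: an estimate of 2.5 ug/mL, ranging from 0.8 ug/mL to 8 ug/mL, which means an expected step of a 1.2-fold higher number from compound 1 to compound 4 (0.08 log units; within the scatter).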

Compound 4, half-maximal inhibitory concentration: 2.3 ug/mL
The estimate for compound 4 lay 1.1-fold (0.04 log units) above the measured number; low and high end bracket the measured number.
By their numbers in this assay, from the lowest: compound 2; then compounds 1, 4 and 3 (each within the scatter of the next).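

In this assay, the only change shown at this position, on an aromatic carbon para to a large group, is a 1.1-fold higher number from compound 1 to compound 4 (0.04 log units; within the scatter), so a swap of fluoro for dimethylamino, with three heavy atoms entering for one and a hydrogen-bond acceptor added, leaves the number within the scatter in this one pair. The earlier compounds shown here spoke only to another aromatic carbon, where a single small exchange could already pass the scatter, as in a 2.6-fold lower number from compound 1 to compound 2 (0.42 log units; beyond the scatter), whereas this larger exchange at the new position does not. Nothing available accounts for this outcome, and no measured property of either group bears on it.

With only fluoro and dimethylamino shown at this position, it remains open whether a primary amine, a methoxy group or a carboxylic acid placed there would also leave the number unmoved. It is also open whether dimethylamino would hold the lower number of compound 2 if combined with the fluoro that compound 2 carries on its other aromatic ring, since no compound shown changes both places at once.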